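Ethylsulfonyl to propylsulfonyl on an inactive orexin-1 pair

The source may report more compounds than this note shows. Statements on the series, on what has been measured and on what is new or still open speak of the compounds shown alone.

Measured so far:
- compound 1, `CCS(=O)(=O)N[C@H]1CCCN(C(C)=O)[C@H]1CO[C@H]1CC[C@@H](C(C)C)CC1`: > 100000 nM
- compound 2, `CCS(=O)(=O)N[C@H]1CCCN(C(C)=O)[C@H]1CO[C@H]1CC[C@H](C(C)C)CC1`: > 100000 nM

In a functional assay on CHO-K1 cells for agonist activity at Orexin/Hypocretin receptor type 1 (Homo sapiens), read by FLIPR and calcium flux (a higher number here means that more compound is needed for the effect, a lower number that less compound is needed), compound 1 gives > 100000 nM, which is a limit of the assay and not a number. Compound 2 likewise gives > 100000 nM in this assay, again a limit. The step that the two limits leave unreadable from compound 1 to compound 2 therefore cannot be read; it rests on the limit of > 100000 nM in this assay, at which 2 of the 2 values shown sit, and (the fact that compounds 1 and 2 differ only in the configuration as drawn), and neither limit fixes where compound 1 truly stands.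

The unmeasured compound 3, `CCCS(=O)(=O)N[C@H]1CCCN(C(C)=O)[C@H]1CO[C@H]1CC[C@@H](C(C)C)CC1`, differs from compound 1 by methyl in place of hydrogen on a saturated chain carbon, two bonds along the chain from a sulfonyl sulfur. Going by the values given here, no measured step bears on this change, and the only step that exists between the measured compounds is itself unreadable. With compound 1 sitting at a limit, no direction can be derived, and a step of the size a step that the limit leaves unreadable from compound 1 to compound 3 is expected, meaning no readable movement. Compound 3 is thus estimated at 120000 nM, with a range of 30000 nM to 500000 nM, most likely again reported as a limit.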

Compound 3, half-maximal effective concentration: > 100000 nM
Compound 3: only a limit was reported (the forecaster's own chance of this, stated with the estimate: 85%); the middle value does not contradict the limit.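

Going by these compounds alone, compound 1 and compound 3 are both reported only as limits, not numbers, so no step between them can be read. The compounds shown leave open where each truly stands and whether any structural change in this series gives a readable value in this assay at all.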